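The compounds below may be only part of what the source reports. "The series", "measured", "known", "first", "only" and "open" are said of these compounds alone.

Compound 1 `CCC(=O)c1cnn2c(-c3ccc(Cl)cc3Cl)c(CN)c(C)nc12`: > 30000 nM in an assay on isolated protein for inhibition of Dipeptidyl peptidase 9 (Homo sapiens) (on this read-out higher numbers stand for weaker inhibition and lower numbers for stronger inhibition), a limit of the assay.
Compound 2 `CCN(CC)c1nc2nc(C)c(CN)c(-c3ccc(Cl)cc3Cl)n2n1`: > 30000 nM in this assay, also a limit.

Compound 2 therefore stands at the limit of > 30000 nM in this assay, at which 2 of the 2 values shown sit, with no number of its own. Compound 3 `Cc1nc2nc(-c3ccccc3)nn2c(-c2ccc(Cl)cc2Cl)c1CN` differs from it by phenyl in place of diethylamino on an aromatic carbon. No measured step of this kind is shown, so no size or direction can be read off. The expected step is a step that the limit leaves unreadable from compound 2 to compound 3, no change beyond the usual scatter. For compound 3 the estimate in this assay is 40000 nM, between 10000 nM and 150000 nM, most likely reported again only as a limit.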

Compound 3, inhibition constant: > 30000 nM
Compound 3 gave a limit, no number (the forecaster's own chance of this, stated with the estimate: 80%); the middle value lies beyond the limit too.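

Compound 2 and compound 3 both give only a limit, so no step between them can be read: the limit of > 30000 nM in this assay, at which 3 of the 3 values shown sit.

The compounds shown leave open whether phenyl in place of diethylamino changes inhibition at all in this assay.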